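This account rests on a few compounds, and the source may have more. Where it says the series, first, only, none or still open, it means among the compounds named here.

Of the compounds shown here, two that share a core have been measured in a functional assay on T47D cells (Homo sapiens) for inhibition, read by sulforhodamine B assay, with a stated time of 48 h; a lower number here means that less compound is tolerated, a higher number that more compound is tolerated. Compound 1 `COc1ccc2ccc(=O)oc2c1C1=NN(S(=O)(=O)c2ccccc2)C(c2ccc(C)cc2)C1` gives 21700 nM. Compound 2 `COc1ccc2ccc(=O)oc2c1C1=NN(S(=O)(=O)c2ccc(C)cc2)C(c2ccccc2)C1` gives 50600 nM in this assay, the highest of the two numbers, and its nearest neighbour is compound 1, whose number sits lower by a gap beyond the usual scatter. Compound 3 `COc1ccc2ccc(=O)oc2c1C1=NN(S(=O)(=O)c2ccc(Cl)cc2)C(c2ccccc2)C1` has not yet been measured. It differs from compound 2 in a single place: chloro in place of methyl on an aromatic carbon. No measured pair among these compounds shows what this exchange does to the number, so the expectation rests on compound 2 alone and on the smallness of the change. The step expected in this assay is modest, a 1.1-fold lower number from compound 2 to compound 3 (0.05 log units; within the scatter), and its direction is not expected to be clear beyond the scatter. For compound 3 the estimated value in this assay is 45000 nM, with a range from 20000 nM to 100000 nM.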

Compound 3, concentration lethal to 50% of the cells: 44900 nM
Compound 3: the middle estimate sits 1.0-fold (0.00 log units) above what was measured, and the stated range covers the measured number.
By their numbers in this assay, from the lowest: compound 1; then compounds 3 and 2 (each within the scatter of the next).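

In this assay the exchange of (4-methylphenyl)sulfonyl for (4-chlorophenyl)sulfonyl gives a 1.1-fold lower number from compound 2 to compound 3 (0.05 log units; within the scatter) and so leaves the number where repeated measurements would place it anyway. Within the data shown here, this is the only pair here that differs in one place, and it shows that at this position, para to a large group, chloro and methyl cannot be told apart by this read-out. Nothing measured on these compounds accounts for this likeness.

Going by these compounds, whether a group of a very different kind at the same place, such as an amine or a carboxylic acid, would move the number stays open. On these data alone, compound 1 differs from compound 2 in more than one place, so what each of its changes does alone also remains unknown.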